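A few compounds are considered here, and "the series" means these few. Any claim that something is new, unique, unknown or untested is made for them only; others in the source may bear on it.

Compound 3 `O=C(Oc1ccc([N+](=O)[O-])cc1)N1CCN(S(=O)(=O)c2ccc(Oc3cccc(Cl)c3)cc2)CC1` gives 380 nM in an assay on isolated protein for inhibition of Fatty-acid amide hydrolase 1 (Homo sapiens), read by fluorescence (a higher number here means a weaker inhibitor, a lower number a stronger inhibitor), the lowest of the three numbers shown. Compound 1 `O=C(Oc1ccc([N+](=O)[O-])cc1)N1CCN(S(=O)(=O)c2ccc(-c3ccc(Cl)c(Cl)c3)cc2)CC1` gives 382 nM and compound 2 `O=C(Oc1ccc([N+](=O)[O-])cc1)N1CCN(S(=O)(=O)c2ccc(-c3ccccc3)cc2)CC1` gives 437 nM. The two steps are a 1.0-fold lower number from compound 1 to compound 3 (0.00 log units; within the scatter) and a 1.2-fold lower number from compound 2 to compound 3 (0.06 log units; within the scatter), both within the scatter, so the three stand together. Compound 4 `O=C(Oc1ccc([N+](=O)[O-])cc1)N1CCN(S(=O)(=O)c2ccc(Oc3ccccc3Cl)cc2)CC1` differs from compound 3 by 2-chlorophenyl in place of 3-chlorophenyl on an oxygen on an aromatic ring. Among the measured compounds shown here, no measured step moves a chlorine around a ring; the nearest comparisons, a 1.1-fold higher number from compound 1 to compound 2 (0.06 log units; within the scatter) and a 1.2-fold lower number from compound 2 to compound 3 (0.06 log units; within the scatter), exchange the whole distal group and still stay within the scatter. The expectation is therefore no step beyond the scatter, a 1.1-fold higher number from compound 3 to compound 4 (0.02 log units; within the scatter). Compound 4 is estimated at 400 nM, with a range of 200 nM to 800 nM.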

Compound 4, half-maximal inhibitory concentration: 1150 nM
Compound 4: the middle estimate sits 2.9-fold (0.46 log units) below what was measured; measured number above the stated range.
By their numbers in this assay, from the lowest: compounds 3, 1 and 2 (each within the scatter of the next); then compound 4.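

Putting 2-chlorophenyl in place of 3-chlorophenyl on the oxygen gives a step beyond the scatter (a 3.0-fold higher number from compound 3 to compound 4 (0.48 log units; beyond the scatter)), so the place of the chlorine on this ring matters here, although exchanging the whole distal group among compounds 1, 2 and 3 moved nothing beyond the scatter. Compound 4 stands apart from the other two as well (a 2.6-fold higher number from compound 2 to compound 4 (0.42 log units; beyond the scatter); a 3.0-fold higher number from compound 1 to compound 4 (0.48 log units; beyond the scatter)). Nothing measured here accounts for the shift.

Open, on these data alone, is whether the step belongs to chlorine itself: a methoxy or a nitrile in place of the chlorine of 2-chlorophenyl would test that.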